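The source may hold more compounds than are shown below. What is called first, only, known or untested is meant among the compounds shown, and "the series" means these compounds.

Measured compounds:
- compound 1, `C[C@@H]1O[C@@H](OCC#Cc2c(-c3ccccc3)[nH]c3ccccc23)C[C@H](N)[C@@H]1O`: 8.8%
- compound 2, `Cc1ccc(S(=O)(=O)n2c(-c3ccccc3)c(C#CCO[C@H]3C[C@H](N)[C@H](O)[C@H](C)O3)c3ccccc32)cc1`: 80.1%

In an assay on isolated protein for inhibition of DNA topoisomerase 1 (Homo sapiens), with a stated time of 30 min, tested at 100 uM (a higher number here means more inhibition at the concentration tested (going by the name of the read-out), a lower number less inhibition), compound 1 gives 8.8%, the lower of the two numbers seen so far. Its nearest neighbour is compound 2, and the step between them is a number 71.3 percentage points higher from compound 1 to compound 2 (beyond the scatter). That step replaces the hydrogen on the aromatic nitrogen with (4-methylphenyl)sulfonyl and leaves the sugar-like ring untouched.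

Compound 3, `C[C@@H]1O[C@@H](OCC#Cc2c(-c3ccccc3)[nH]c3ccccc23)CC[C@@H]1N`, has not yet been measured in this assay. It differs from compound 1 at the other end of the molecule: a group of 8 heavy atoms (6 carbon, 1 nitrogen, 1 oxygen; one six-membered non-aromatic ring with 1 hetero atom) in place of a group of 9 heavy atoms (6 carbon, 1 nitrogen, 2 oxygen; one six-membered non-aromatic ring with 1 hetero atom), on an oxygen on a saturated carbon. The ring that enters carries one fewer hydrogen-bond donor and one fewer acceptor than the ring it replaces, while the aromatic nitrogen keeps its hydrogen.

Among the measured compounds shown here, no measured step touches this part of the molecule. For the measured compounds named here, the only step known, from compound 1 to compound 2, concerns the aromatic nitrogen and so does not bear on this change. With nothing to suggest otherwise, the change is expected to give no step beyond the scatter, so compound 3 is estimated at 8%, in a range from 0% to 22%, which means an expected step of a number 0.8 percentage points lower from compound 1 to compound 3 (within the scatter).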

Compound 3, a percentage reported as inhibition, at one concentration (the size of the read-out at that concentration, not a potency): 4%
Compound 3: the middle estimate sits 4 percentage points above what was measured, and the stated range covers the measured number.
By their numbers in this assay, from the lowest: compounds 3 and 1 (each within the scatter of the next); then compound 2.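

In this assay, among the compounds shown here, replacing the group of 9 heavy atoms on the oxygen on a saturated carbon with 5-amino-6-methyloxan-2-yl, a group of 8 heavy atoms, gives a number 4.8 percentage points lower from compound 1 to compound 3 (within the scatter) and provides the first reading at this end of the molecule. The ring can therefore undergo this particular change without a step beyond the scatter, although both compounds keep the hydrogen on the aromatic nitrogen, so the reading applies only to that setting. Nothing measured offers an explanation for this result.

On these data alone, it remains open whether 5-amino-6-methyloxan-2-yl would also leave the number unchanged when the aromatic nitrogen carries the (4-methylphenyl)sulfonyl group found in compound 2, where the inhibition read-out is much higher and a change in the ring might show up more clearly. Also open, as far as these compounds go, is whether a different group on this ring, such as a dimethylamino group in place of the amine, would produce a step beyond the scatter on this same core.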